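The compounds below may be only part of what the source reports. "The series", "measured", "known", "first", "only" and "open" are said of these compounds alone.

Measured compounds:
Compound 1: `COc1cc2c(cc1C)NC(=O)/C2=C/c1c(OC)nc2sc(C)cn12` — 4570 nM
Compound 2: `O=C1Nc2ccccc2C1=Cc1c(-c2ccncc2)nc2sccn12` — 5420 nM

Both compounds were tested in a functional assay on cells (Breast carcinoma cell, Homo sapiens) for cytotoxicity, read by sulforhodamine B assay, with a stated time of 48 h; a higher number here means a weaker inhibitor of growth, a lower number a stronger inhibitor of growth. Compound 1 gives the lower of the two numbers, 4570 nM, while compound 2 gives 5420 nM; the gap between them lies within the scatter of repeated measurements, so the two compounds cannot be told apart on these data. Going by the values given here, no step between measured compounds that differ in one place is available, and compound 2 differs from compound 1 in several places at once.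

Compound 3, `COc1ccc2c(c1)/C(=C\c1c(OC)nc3sc(C)cn13)C(=O)N2`, has not yet been measured. It differs from compound 1 by one change: hydrogen in place of methyl on an aromatic carbon. The methyl is lost from an aromatic carbon of the six-membered aromatic ring of carbon only, ortho to a methoxy group; no hydrogen-bond donor or acceptor is gained or lost.

Among the compounds with values here, with no measured step of this kind to lean on, the expectation for compound 3 is a step from compound 1 of a 1.2-fold higher number from compound 1 to compound 3 (0.08 log units; within the scatter) in this assay, essentially none beyond the scatter, with perhaps a slight drift toward the weaker side. Compound 3 is therefore expected to give about 5500 nM in this assay, within a range from 2500 nM to 12000 nM.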

Compound 3, concentration for 50% growth inhibition: 870 nM
Compound 3: middle estimate off by 6.3-fold (0.80 log units), on the high side; measured number below the stated range.
By their numbers in this assay, from the lowest: compound 3; then compounds 1 and 2 (each within the scatter of the next).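

Going by these compounds alone, the single change of hydrogen in place of methyl gives a 5.3-fold lower number from compound 1 to compound 3 (0.72 log units; beyond the scatter) in this assay, and this separates two compounds by more than the scatter, which the earlier pair could not do. It shows that this aromatic carbon, ortho to a methoxy group, is a place where the read-out responds to the loss of one methyl, and that in this pair the compound carrying hydrogen is the stronger inhibitor of growth. Nothing measured here accounts for the size of this step or tells what lies behind it.

The compounds shown rest this finding on one pair, so they leave open whether a group other than methyl on this carbon, such as a chlorine, a hydroxyl, an amine or a longer chain such as ethyl, would give a number closer to that of compound 3 or to that of compound 1. They also leave open whether the same change would have a step of similar size on a different core, or in the absence of the methoxy group.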